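The source may report more compounds than this note shows. Statements on the series, on what has been measured and on what is new or still open speak of the compounds shown alone.

Measured compounds:
compound 1 `Cc1n[nH]cc1-c1cccc2c1CCC2c1ncc[nH]1` with 634 nM
compound 2 `c1ccc(-c2cccc3c2CCC3c2ncc[nH]2)nc1` with > 10000 nM

In a functional assay on CHO cells for agonist activity at Alpha-1D adrenergic receptor (Homo sapiens), read by FLIPR and calcium flux (a lower number here means that less compound is needed, a higher number that more compound is needed for the effect), compound 2 gives only a limit, > 10000 nM; this is the limit of > 10000 nM in this assay, at which 1 of the 2 values shown sits. Compound 3 is `CCCS(=O)(=O)Nc1cccc2c1CCC2c1ncc[nH]1`. Its change from compound 2 is (propylsulfonyl)amino in place of pyridin-2-yl on an aromatic carbon. For the measured compounds named here, only one measured step touches this position: an at least 15-fold higher number from compound 1 to compound 2 (1.19 log units; beyond the scatter), which shows the group there can move the number strongly. Compound 1, which carries a hydrogen-bond donor in its substituent, gives 634 nM. Since compound 3 also brings a donor, a gain is expected for it, an at least 6.6-fold lower number from compound 2 to compound 3 (0.82 log units; beyond the scatter), though the size is uncertain from a limit. Compound 3 is estimated at 1500 nM, between 200 nM and 10000 nM.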

Compound 3, half-maximal effective concentration: > 10000 nM
Compound 3 gave a limit, no number; the forecaster's own chance of this, stated with the estimate: 35%; middle value at least 6.6-fold (0.82 log units) away from the limit.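

Putting (propylsulfonyl)amino in place of 3-methyl-1H-pyrazol-4-yl gives an at least 15-fold higher number from compound 1 to compound 3 (1.19 log units; beyond the scatter) in this assay. A hydrogen-bond donor in the substituent is therefore not enough on its own at this aromatic carbon to keep a value like that of compound 1. The step between compound 2 and compound 3 cannot be read, because both values are limits: the limit of > 10000 nM in this assay, at which 2 of the 3 values shown sit.

As far as these compounds go, how far compound 2 and compound 3 lie past that limit remains open. So does whether a plain amine or a carboxylic acid on this aromatic carbon would give a measurable value.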